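A few compounds are considered here, and "the series" means these few. Any claim that something is new, unique, unknown or untested is made for them only; others in the source may bear on it.

Compound 1 `Cc1ccc(S(=O)(=O)c2cnc3cc(F)ccc3c2N2CCC(C)CC2)cc1C` gives 90% in an assay on isolated protein for displacement of a labelled ligand from metabotropic glutamate receptor 5 (Homo sapiens), with a stated time of 60 min, tested at 1 uM; on this read-out lower numbers stand for less inhibition and higher numbers for more inhibition at the one concentration tested (going by the name of the read-out). Compound 2 `CC1CCN(c2c(S(=O)(=O)c3ccc(C#N)cc3)cnc3cc(Cl)ccc23)CC1` gives 70% in this assay. Compound 3 `CC1CCN(c2c(S(=O)(=O)c3cccc(C#N)c3)cnc3cc(F)ccc23)CC1` gives 92% in this assay.

Compound 3 carries the largest of the three numbers, but its gap to compound 1 lies within the scatter, so the two cannot be told apart; only compound 2 sits clearly lower. Compound 4 `CC1CCN(c2c(S(=O)(=O)c3ccc(C#N)cc3)cnc3cc(F)ccc23)CC1` differs from compound 3 in one place: 4-cyanophenyl in place of 3-cyanophenyl on a sulfonyl sulfur. Among the measured compounds shown here, the one measured step that touches the same position is a number 2 percentage points higher from compound 1 to compound 3 (within the scatter), which shows that swapping the group on the sulfonyl sulfur left the read-out essentially unchanged in that case. Compound 2 already carries 4-cyanophenyl on that sulfur, yet it also differs from compound 3 in the halogen on the shared core, so its lower value cannot be pinned on the cyanophenyl group alone. A small drop, or no change beyond the scatter, is therefore expected, with the step of a number 12 percentage points lower from compound 3 to compound 4 (beyond the scatter) estimated for this assay. Compound 4 is expected to give about 80%, between 60% and 95%.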

Compound 4, a percentage reported as inhibition, at one concentration (the size of the read-out at that concentration, not a potency): 83%
Beside the measured number, compound 4's estimate is 3 percentage points below it; measured number inside the range.
By their numbers in this assay, from the lowest: compound 2; then compounds 4, 1 and 3 (each within the scatter of the next).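

Putting 4-cyanophenyl in place of 3-cyanophenyl on a sulfonyl sulfur gives a number 9 percentage points lower from compound 3 to compound 4 (within the scatter), while 4-cyanophenyl in place of 3,4-dimethylphenyl gives a number 7 percentage points lower from compound 1 to compound 4 (within the scatter), so all three groups at this position remain within the scatter of one another in this assay. The halogen can now be read separately: fluoro in place of chloro on an aromatic carbon gives a number 13 percentage points higher from compound 2 to compound 4 (beyond the scatter), so the lower number of compound 2 goes with the chloro rather than with its 4-cyanophenyl group. No measurement available here explains these steps.

As far as these compounds go, whether a methyl or cyclohexyl group on the sulfonyl sulfur would keep the read-out this high remains open. So does whether a methoxy group in place of the halogen would shift it, and whether chloro would lower the number with 3-cyanophenyl on the sulfur.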